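Swapping a Bromophenyl for a Hydroxyphenyl: What to Expect

A few compounds are considered here, and "the series" means these few. Any claim that something is new, unique, unknown or untested is made for them only; others in the source may bear on it.

Compound 1, `COc1ccc2c(c1)CC/C(=C\c1ccccc1C)C2=O`: in an assay on mitochondria for inhibition of 1,25-dihydroxyvitamin D(3) 24-hydroxylase, mitochondrial (Rattus norvegicus) (on this read-out lower numbers stand for stronger inhibition and higher numbers for weaker inhibition), compound 1 gives > 20000 nM, which is a limit of the assay rather than a number.
Compound 2, `COc1ccc2c(c1)CC/C(=C\c1ccccc1Br)C2=O`: in this assay compound 2 gives 100000 nM.

Compound 2 thus carries the only number shown in this assay; the other value shown is a limit. Within the data shown here, the single measured step, a step that the limit leaves unreadable from compound 1 to compound 2, cannot be read in size, as the limit of > 20000 nM in this assay, at which 1 of the 2 values shown sits, shows. Compound 3, `COc1ccc2c(c1)CC/C(=C\c1ccc(O)cc1)C2=O`, differs from compound 2 by 4-hydroxyphenyl in place of 2-bromophenyl on a double-bonded chain carbon bound to a double-bonded ring carbon. Among the measured compounds shown here, no measured step bears directly on this exchange: the only step available starts from a limit, and no measured compound carries a hydroxyphenyl. The expectation for compound 3 is therefore a step of a 1.4-fold lower number from compound 2 to compound 3 (0.15 log units; within the scatter), not beyond the usual scatter in either direction. Compound 3 is expected at 70000 nM, between 15000 nM and 300000 nM, with a fair chance that only a limit is reported.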

Compound 3, half-maximal inhibitory concentration: > 20000 nM
Compound 3 gave a limit, no number; the forecaster's own chance of this, stated with the estimate: 40%; the middle value is on the limit's open side.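

Neither the step from compound 2 to compound 3 nor the one from compound 1 to compound 3 can be read in size, because both involve a limit rather than a number: the limit of > 20000 nM in this assay, at which 2 of the 3 values shown sit.

The compounds shown leave open whether 4-hydroxyphenyl in place of 2-bromophenyl changes the inhibition at all.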